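The source may hold more compounds than are shown below. What is called first, only, known or untested is meant among the compounds shown, and "the series" means these compounds.

Measured in a functional assay on Caco-2 cells (Homo sapiens) for inhibition, read by MTT assay, with a stated time of 48 h, tested at 10 uM (a lower number here means less inhibition of growth, a higher number more inhibition of growth at the concentration tested), so far:
compound 1 `Cc1cc(=O)c2c(O)c(CN3CCCCC3)c(O)c([C@H]3CCN(C)C[C@H]3O)c2o1` gives 22%
compound 2 `Cc1oc2c([C@H]3CCN(C)C[C@H]3O)c(O)cc(O)c2c(=O)c1C(O)c1cccc(Cl)c1` gives 4%

Compound 2 holds the lower of these two numbers, and the gap up to compound 1 lies beyond the scatter of this kind of measurement. The two compounds differ in more than one place, so that gap says little about any single change.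

Compound 3 `Cc1oc2c([C@H]3CCN(C)C[C@H]3O)c(O)cc(O)c2c(=O)c1C(O)c1cc(F)cc(F)c1` is compound 2 with one group exchanged: 3,5-difluorophenyl in place of 3-chlorophenyl on a saturated chain carbon bound to an aromatic carbon and an oxygen on a saturated carbon In words, it carries 3,5-difluorophenyl in place of 3-chlorophenyl on a saturated chain carbon bound to an aromatic carbon and an oxygen on a saturated carbon. The rest of the structure stays the same.

For the measured compounds named here, no measured pair shows what an exchange of this kind does, so the expectation is cautious. Compound 2 gives 4% and so shows almost no inhibition of growth, and one exchange on an aryl group is expected to leave that largely as it is. The estimated step of a number 3 percentage points higher from compound 2 to compound 3 (within the scatter) is small, upward if anything, and expected to stay within the scatter. Compound 3 is estimated at 7% in this assay with an expected range from 0% to 18% as its upper end.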

Compound 3, percent growth inhibition at one concentration: 10%
Compound 3: the middle estimate sits 3 percentage points below what was measured; the measured number falls inside the stated range.
By their numbers in this assay, from the lowest: compounds 2 and 3 (each within the scatter of the next); then compound 1.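

In this assay, putting 3,5-difluorophenyl in place of 3-chlorophenyl on this saturated chain carbon gives a number 6 percentage points higher from compound 2 to compound 3 (within the scatter). For the compounds shown here, this is the first single exchange that can be read, and it shows that these two halogen-bearing phenyl groups cannot be told apart at this position at the one concentration tested, so the exchange has not revealed a way to raise growth inhibition here. Nothing at hand bears on why these two groups read alike.

Both groups compared here are phenyl rings carrying halogen atoms, so the compounds shown leave open whether a different kind of group on this carbon, such as an unsubstituted phenyl, a pyridine ring, an amine or a carboxylic acid, would give a step beyond the scatter. They also leave open what the hydroxy group on the same carbon contributes, which a methoxy group in its place could test while the 3-chlorophenyl or 3,5-difluorophenyl group and the rest of the shared core stay the same.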